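The compounds below may be only part of what the source reports. "The series", "measured", "known", "first", "only" and "open" are said of these compounds alone.

Measured in a functional assay on DU-145 cells (Homo sapiens) for inhibition, read by trypan blue exclusion, with a stated time of 96 h; a higher number here means a weaker inhibitor of growth, a lower number a stronger inhibitor of growth:
- compound 1 `O=C(/C(=C\c1ccc(OCc2ccccc2)cc1)SCc1cccc(Cl)c1)c1ccc(Br)cc1` gives 1000 nM
- compound 2 `COc1ccc(C(=O)/C(=C\c2ccc(OC)c(O)c2)Sc2ccc(F)cc2)cc1` gives 1000 nM

Compound 2 stands level with compound 1, as the two values lie within the usual scatter of this kind of measurement. The next compound, compound 3 `COc1ccc(C(=O)/C(=C\c2ccc(Cl)cc2)Sc2ccc(F)cc2)cc1`, differs from compound 2 in one place (4-chlorophenyl in place of 3-hydroxy-4-methoxyphenyl on a double-bonded chain carbon bound to a double-bonded chain carbon), with 4-chlorophenyl in place of 3-hydroxy-4-methoxyphenyl on a double-bonded chain carbon bound to a double-bonded chain carbon. For the measured compounds named here, no measured pair shows what such a swap does in this assay so far, which makes any forecast loose. Compound 1 has no hydroxy group, and compound 1 at 1000 nM still matches compound 2, so only a modest shift towards weaker growth inhibition is expected, perhaps hardly beyond the scatter. The estimated change is a 2.0-fold higher number from compound 2 to compound 3 (0.30 log units; within the scatter) in size. For compound 3 the expected value is 2000 nM within an estimated range of 500 nM to 10000 nM overall.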

Compound 3, concentration for 50% growth inhibition: > 100000 nM
Compound 3: a limit, no number; the forecaster's own chance of this, stated with the estimate: 10%; middle value at least 50-fold (1.69 log units) from the limit.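

For the compounds shown here, the step from 3-hydroxy-4-methoxyphenyl to 4-chlorophenyl on a double-bonded chain carbon bound to a double-bonded chain carbon is the first single-place change in this set, and it is large: an at least 100-fold higher number from compound 2 to compound 3 (2.00 log units; beyond the scatter). In this assay, going by these compounds alone, compound 3 gives a limit and not a number: the limit of > 100000 nM in this assay, at which 1 of the 3 values shown sits. The group at this position can therefore make a very large difference to growth inhibition, which the earlier compounds, differing in several places at once, could not show.

This one swap removes a hydroxy group and a methoxy group and adds a chlorine, so the compounds shown do not reveal which of these changes matters. As far as these compounds go, it also remains open how a phenyl ring carrying only a hydroxy group, or an amine in its place, would behave here.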